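Phenyl to thiophene on the triazole arm of compound 3

The compounds below may be only part of what the source reports. "The series", "measured", "known", "first", "only" and "open" are said of these compounds alone.

Measured so far:
Compound 1, `CCS[C@@H]1[C@H](SCC)[C@@H](Cn2cc(-c3ccccc3)nn2)O[C@H]1n1ccc(=O)[nH]c1=O`: 6590 nM in a functional assay on HeLa cells (Homo sapiens) for cytotoxicity, read by MTT assay, with a stated time of 72 h; a higher number here means that more compound is needed for the effect, a lower number that less compound is needed.
Compound 2, `CCOC(=O)c1cn(C[C@H]2O[C@@H](n3ccc(=O)[nH]c3=O)[C@H](SCC)[C@@H]2SCC)nn1`: in this assay compound 2 reaches only a limit of the assay, >= 100000 nM.
Compound 3, `CCS[C@@H]1[C@H](SCC)[C@@H](Cn2cc(-c3ccccc3)nn2)O[C@H]1n1cc(C)c(=O)[nH]c1=O`: 1890 nM in this assay.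

Compound 3 stands lowest of the two numbers that are not limits. Its nearest neighbour is compound 1, and the step is a 3.5-fold lower number from compound 1 to compound 3 (0.54 log units; beyond the scatter), a modest change from adding a methyl group. Compound 4, `CCS[C@@H]1[C@H](SCC)[C@@H](Cn2cc(-c3cccs3)nn2)O[C@H]1n1cc(C)c(=O)[nH]c1=O`, differs from compound 3 in one place: thiophen-2-yl in place of phenyl on an aromatic carbon.

Among the compounds with values here, only one measured step touches the same position, namely an at least 15-fold higher number from compound 1 to compound 2 (1.18 log units; beyond the scatter), where an ethoxycarbonyl group replaced phenyl and the value ran into (the limit of >= 100000 nM in this assay, at which 1 of the 3 values shown sits). That step exchanged an aromatic ring for a non-ring group, whereas compound 4 keeps an aromatic ring at this position, so the measured steps give no direct guide for the thiophene swap. With no closer evidence, the expected step of a 1.1-fold higher number from compound 3 to compound 4 (0.02 log units; within the scatter) is within the scatter, in no clear direction. Compound 4 is therefore estimated at 2000 nM, with a range from 700 nM to 6000 nM.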

Compound 4, half-maximal effective concentration: 54900 nM
Compound 4: the middle estimate sits 27-fold (1.44 log units) below what was measured, and the stated range ends below it.
By their numbers in this assay, from the lowest: compound 3; then compound 1; then compound 4. At a limit, above all of these: compound 2.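

Keeping an aromatic ring on the triazole arm does not by itself preserve activity in this assay, since a 29-fold higher number from compound 3 to compound 4 (1.46 log units; beyond the scatter) and much more compound is needed for the effect. Before this, the only large change at this position came from replacing the ring with ethoxycarbonyl, so the choice of ring now turns out to matter as well. Nothing shown explains why thiophen-2-yl, a five-membered ring containing sulfur, behaves so differently from phenyl, a six-membered ring of carbon only.

From the compounds shown here alone, it remains open whether this loss is specific to thiophen-2-yl or extends to other replacements for phenyl, such as a pyridine ring or a phenyl ring carrying a methoxy group. Going by these compounds, whether the same swap would have a similar effect on compound 1, which lacks the added methyl group, also remains open.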